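Sulfur side chain swap from compound 1 to compound 4

The source may hold more compounds than are shown below. What is called first, only, known or untested is meant among the compounds shown, and "the series" means these compounds.

Measured in an ADME assay on GES1 cells (Homo sapiens) for inhibition, read by MTT assay, with a stated time of 72 h; a lower number here means a stronger inhibitor, a higher number a weaker inhibitor:
- compound 1 `Cc1cc(Nc2cc(-c3ccccc3)[nH]n2)n2nc(SCc3c(Cl)cccc3Cl)nc2n1` gives 39600 nM
- compound 2 `Cc1cc(Nc2ccn(Cc3ccccc3)n2)n2nc(SCc3ccc(Br)cc3)nc2n1` gives 44400 nM
- compound 3 `CCCCCc1c(C)nc2nc(SCc3ccc(Cl)cc3)nn2c1Nc1cc(-c2ccccc2)[nH]n1` gives > 50000 nM

Compound 1 and compound 2 lie within the scatter of each other. The reading for compound 3 is a limit of the assay, not a number.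

Compound 4 `Cc1cc(Nc2cc(-c3ccccc3)[nH]n2)n2nc(SCCCc3ccccc3)nc2n1` keeps the core of compound 1 and changes on a saturated chain carbon bound to a sulfur: phenethyl in place of 2,6-dichlorophenyl on a saturated chain carbon bound to a sulfur. This reads as 2,6-dichlorobenzyl to 3-phenylpropyl. Within the data shown here, no measured pair isolates this change, so no step beyond the scatter is expected in this assay. The expected change is a 1.1-fold higher number from compound 1 to compound 4 (0.03 log units; within the scatter). For compound 4 the estimated value is 42000 nM, with an expected range of 18000 nM to 80000 nM.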

Compound 4, half-maximal inhibitory concentration: 40200 nM
The estimate for compound 4 lay 1.0-fold (0.02 log units) above the measured number; the measured number falls inside the stated range.
By their numbers in this assay, from the lowest: compounds 1, 4 and 2 (each within the scatter of the next). At a limit, above all of these: compound 3.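

In this assay, among these compounds, replacing 2,6-dichlorobenzyl with 3-phenylpropyl on a saturated chain carbon bound to a sulfur gives a 1.0-fold higher number from compound 1 to compound 4 (0.01 log units; within the scatter) as the only single-place step so far. At this position, removing both chlorines and changing the chain together leave the reading unmoved, although the two changes are not separated here. Compound 3 is recorded only as a limit, not a number: the limit of > 50000 nM in this assay, at which 1 of the 4 values shown sits.

As far as these compounds go, whether an amine or a carboxylic acid in the sulfur side chain would give a step beyond the scatter remains open. So does the separate contribution of the chlorines and the chain.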